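The source may report more compounds than this note shows. Statements on the series, on what has been measured and on what is new or still open speak of the compounds shown alone.

Measured compounds:
- compound 1 `Cn1c(-c2ccc(NC(=O)CSc3nc4ccccc4o3)cc2)nc(-c2ccccc2)c1-c1ccccc1` gives 44.9% in a functional assay on HT-29 cells (Homo sapiens) for cytotoxicity, read by MTT assay, with a stated time of 24 h, tested at 6.4 ug/mL; on this read-out lower numbers stand for a weaker effect and higher numbers for a stronger effect at the one concentration tested
- compound 2 `Cn1ccnc1SCC(=O)Nc1ccc(-c2nc(-c3ccccc3)c(-c3ccccc3)n2C)cc1` gives 30.7%
- compound 3 `CN1CCN(CC(=O)Nc2ccc(-c3nc(-c4ccccc4)c(-c4ccccc4)n3C)cc2)CC1` gives 28.8%

Compound 1 stands highest of the three numbers in this assay; compound 2 comes nearest, and compound 3 lies furthest away. Compound 4 `Cn1c(-c2ccc(NC(=O)CN3CCN(c4ccccc4)CC3)cc2)nc(-c2ccccc2)c1-c1ccccc1` has not yet been measured. It differs from compound 1 in one place: 4-phenylpiperazin-1-yl in place of (1,3-benzoxazol-2-yl)sulfanyl on a saturated chain carbon bound to a carbonyl carbon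

Two measured steps from compound 1 bear on this change, and both swap out the same group on the same chain carbon. The step of a number 14.2 percentage points lower from compound 1 to compound 2 (beyond the scatter) and the step of a number 16.1 percentage points lower from compound 1 to compound 3 (beyond the scatter) both lowered the read-out by a modest amount beyond the scatter, with the piperazine-bearing compound 3 the lower of the two. Compound 4 also carries a piperazine in that place, though it keeps a six-membered carbon ring in the group that enters. A downward step is therefore expected, estimated as a number 10.9 percentage points lower from compound 1 to compound 4 (beyond the scatter). Compound 4 is expected to give about 34%, within a range from 22% to 48%.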

Compound 4, a percentage reported as activity, at one concentration (the size of the read-out at that concentration, not a potency): 46.5%
Compound 4: middle estimate off by 12.5 percentage points, on the low side, within the range that was stated.
By their numbers in this assay, from the lowest: compounds 3 and 2 (each within the scatter of the next); then compounds 1 and 4 (each within the scatter of the next).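

In this assay, the sulfur-linked group on this saturated chain carbon can be replaced without a loss in the read-out: the result is a number 1.6 percentage points higher from compound 1 to compound 4 (within the scatter), so the two earlier downward steps do not hold for every replacement at this place. The piperazine ring alone does not set the number, as phenyl in place of methyl on an amine nitrogen in a ring gives a number 17.7 percentage points higher from compound 3 to compound 4 (beyond the scatter). The 4-phenylpiperazin-1-yl group also compares well with the (1-methyl-1H-imidazol-2-yl)sulfanyl group, giving a number 15.8 percentage points higher from compound 2 to compound 4 (beyond the scatter).

No measurement shown here explains why the phenyl group gives this higher number. On these data alone, whether a cyclohexyl or benzyl group on that ring nitrogen would do the same remains open, as does the effect of a chlorine or methoxy group on the phenyl ring.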